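This account rests on a few compounds, and the source may have more. Where it says the series, first, only, none or still open, it means among the compounds named here.

Among the measured compounds shown here, compound 1 `COc1ccccc1/C=C(/SCc1ccc(F)cc1)C(=O)c1ccc(Br)cc1` is the weaker of the two measured members of this pair: in a functional assay on DU-145 cells (Homo sapiens) for inhibition, read by trypan blue exclusion, with a stated time of 96 h (on this read-out lower numbers stand for stronger inhibition of growth and higher numbers for weaker inhibition of growth), compound 1 gives 10000 nM, the highest of the two numbers. For the measured compounds named here, its nearest neighbour, compound 2 `COc1ccccc1/C=C(/SCc1ccc(Cl)cc1)C(=O)c1ccc(Br)cc1`, gives 1000 nM in this assay, and the only measured step, a 10-fold lower number from compound 1 to compound 2 (1.00 log units; beyond the scatter), comes from chloro in place of fluoro on an aromatic carbon. Compound 3 `Cc1cc(F)ccc1/C=C(/SCc1ccc(F)cc1)C(=O)c1ccc(Br)cc1` is built from compound 1 by a change at a different position: 4-fluoro-2-methylphenyl in place of 2-methoxyphenyl on a double-bonded chain carbon bound to a double-bonded chain carbon. Going by the values given here, no measured step touches this part of the shared core, so the one step recorded, which concerns the other aromatic ring, gives no direct guide to the size or direction of the change in this assay. Compound 3 is therefore expected to remain close to compound 1, with a broad range and a step of a 2.0-fold lower number from compound 1 to compound 3 (0.30 log units; within the scatter) that may well fall within the scatter. The estimate for compound 3 in this assay is 5000 nM, from 1000 nM to 25000 nM.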

Compound 3, concentration for 50% growth inhibition: 10000 nM
Beside the measured number, compound 3's estimate is 2.0-fold (0.30 log units) below it, within the range that was stated.
By their numbers in this assay, from the lowest: compound 2; then compounds 1 and 3 (each within the scatter of the next).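

On a double-bonded chain carbon bound to a double-bonded chain carbon, 4-fluoro-2-methylphenyl in place of 2-methoxyphenyl gives, in this assay, no change at the digits printed from compound 1 to compound 3 (within the scatter). Among the compounds shown here, this is the first reading at this position, and it shows that on this pair, exchanging a group that holds an oxygen and a hydrogen-bond acceptor for one that holds a fluorine and no acceptor leaves the number unmoved, unlike the step elsewhere in the molecule, a 10-fold lower number from compound 1 to compound 2 (1.00 log units; beyond the scatter). Nothing available explains this result.

The compounds shown leave open whether the same holds for a different kind of group at this position, such as an aminophenyl, a carboxyphenyl or a pyridine ring. They also leave open whether 4-fluoro-2-methylphenyl would give the same result alongside the chloro group of compound 2.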